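The source may report more compounds than this note shows. Statements on the series, on what has been measured and on what is new or still open speak of the compounds shown alone.

Among the measured compounds shown here, compound 1 `O=C(O)CC1CCCC1Cc1ccc(OCc2ccc3ccccc3n2)cc1` is one of three compounds measured in a functional assay (lung) for inhibition, with Cavia porcellus as the target (on this read-out higher numbers stand for weaker inhibition and lower numbers for stronger inhibition), where compound 1 gives 90 nM. It stands second highest of the three. For the measured compounds named here, compound 2 `c1ccc2nc(COc3ccc(CC4CCCC4Cc4nnn[nH]4)cc3)ccc2c1` gives 20 nM, and the step of a 4.5-fold lower number from compound 1 to compound 2 (0.65 log units; beyond the scatter) is the only single-point change among the measured compounds. Compound 3 `CC(CCC(=O)O)Cc1cccc(OCc2ccc3ccccc3n2)c1` gives 500 nM; it differs from compound 1 in more than one place, so only the two values themselves can be compared, and they show compound 3 with the higher number.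

Compound 4 `CCCC(CCC(=O)O)Cc1ccc(OCc2ccc3ccccc3n2)cc1` differs from compound 1 by 1-(2-carboxyethyl)butyl in place of 2-(carboxymethyl)cyclopentyl on a saturated chain carbon bound to an aromatic carbon. Going by the values given here, no measured step tests this change: the step from compound 1 to compound 2 concerns the acid group and not the ring, and compound 3 is not a single-point neighbour. The closest hint is that the open-chain acid of compound 3 sits at a higher number than compound 1, so a modest weakening is expected rather than a gain, with a step of a 2.2-fold higher number from compound 1 to compound 4 (0.35 log units; beyond the scatter). Compound 4 is therefore expected to give about 200 nM, in a range from 60 nM to 700 nM.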

Compound 4, half-maximal inhibitory concentration: 30 nM
Estimate against measurement, compound 4: 6.7-fold (0.82 log units) above; measured number below the stated range.
By their numbers in this assay, from the lowest: compounds 2 and 4 (each within the scatter of the next); then compound 1; then compound 3.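

In this assay, the step of a 3.0-fold lower number from compound 1 to compound 4 (0.48 log units; beyond the scatter) shows that the five-membered ring of 2-(carboxymethyl)cyclopentyl is not needed for a low number at this position, on a saturated chain carbon bound to an aromatic carbon. Among the compounds shown here, the open-chain 1-(2-carboxyethyl)butyl has the same count of heavy atoms and no ring, yet it gives the lower number, and this is the first single-point reading of this part of the molecule, as the earlier step concerned only the acid group. Nothing at hand accounts for this difference.

The compounds shown leave open how the result depends on the propyl part of the open chain, which could give way to an ethyl group or a longer chain such as pentyl. They also leave open whether 1H-tetrazol-5-yl in place of carboxy would change the number on the open chain of compound 4.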